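The source may report more compounds than this note shows. Statements on the series, on what has been measured and on what is new or still open speak of the compounds shown alone.

Compound 2 `Nc1ccc(-c2cc(=O)c3c(N)c(F)c(C(=O)O)c(F)c3o2)cc1F` carries a carboxy group on the shared core. In a functional assay on HeLa cells (Homo sapiens) for cytotoxicity, read by neutral red uptake, with a stated time of 3 days (a lower number here means a stronger inhibitor, a higher number a weaker inhibitor), compound 2 gives only the assay's limit, > 100000 nM, so no number is known for it. Compound 1 `CCCCCCc1c(F)c(N)c2c(=O)cc(-c3ccc(N)c(F)c3)oc2c1F`, which carries a hexyl group in that place, gives 21000 nM in this assay. Among the compounds with values here, the single measured step, an at least 4.7-fold higher number from compound 1 to compound 2 (0.67 log units; beyond the scatter), is the only guide here, and one of its two values sits at the limit of > 100000 nM in this assay, at which 1 of the 2 values shown sits. Compound 3 `CN(C)CCCOCc1c(F)c(N)c2c(=O)cc(-c3ccc(N)c(F)c3)oc2c1F` removes the carboxy again: (3-(dimethylamino)propoxy)methyl in place of carboxy on an aromatic carbon. As compound 1 without a carboxy gives 21000 nM, taking the carboxy away in compound 3 is expected to bring the number back down, though the new group is larger than hexyl and untested. Compound 3 is therefore estimated at 30000 nM in this assay, most likely between 8000 nM and 100000 nM. That estimate corresponds to an expected step of an at least 3.3-fold lower number from compound 2 to compound 3 (0.52 log units; beyond the scatter).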

Compound 3, half-maximal inhibitory concentration: 12000 nM
Beside the measured number, compound 3's estimate is 2.5-fold (0.40 log units) above it; measured number inside the range.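

Compound 3 shows that the high number of compound 2 is not tied to hexyl alone: a quite different chain at this position, (3-(dimethylamino)propoxy)methyl, also gives a readable value in this assay, with an at least 8.3-fold lower number from compound 2 to compound 3 (0.92 log units; beyond the scatter). Set against the hexyl chain, the new chain gives a 1.8-fold lower number from compound 1 to compound 3 (0.24 log units; within the scatter), so replacing pentyl with 3-(dimethylamino)propoxy at the end of the chain makes no readable difference here, although one chain holds nitrogen and oxygen and the other only carbon. The step from compound 2 gives only a minimum size, not an exact one: the limit of > 100000 nM in this assay, at which 1 of the 3 values shown sits.

The compounds shown leave open whether a methyl ester or a primary amide in this place would behave like the carboxy group, and whether a single methyl group would match the longer chains. They also leave open whether the dimethylamino nitrogen matters, which a chain of the same length ending in plain carbon could test.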